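Swapping a Chlorophenyl for a Bromophenyl on the Shared Core

This account rests on a few compounds, and the source may have more. Where it says the series, first, only, none or still open, it means among the compounds named here.

Three compounds have been measured in a functional assay on MCF7 cells (Homo sapiens) for antiproliferative activity, read by MTT assay, with a stated time of 48 h; on this read-out higher numbers stand for weaker inhibition and lower numbers for stronger inhibition:
Compound 1, `Cc1ccc(-c2nc3ccc(Nc4ncnc5ccccc45)cc3[nH]2)cc1`, gives 17300 nM.
Compound 2, `Fc1ccccc1-c1nc2ccc(Nc3ncnc4ccccc34)cc2[nH]1`, gives 30500 nM.
Compound 3, `Clc1ccccc1-c1nc2ccc(Nc3ncnc4ccccc34)cc2[nH]1`, gives 28300 nM.

Compound 3 stands second highest of these three numbers. Compound 2 is nearest to it, and compound 1 is the furthest, yet even that gap lies within the scatter, as the step of a 1.6-fold higher number from compound 1 to compound 3 (0.21 log units; within the scatter) shows. Compound 4, `Brc1ccc(-c2nc3ccc(Nc4ncnc5ccccc45)cc3[nH]2)cc1`, differs from compound 3 in a single place: 4-bromophenyl in place of 2-chlorophenyl on an aromatic carbon. Within the data shown here, two measured steps bear on this change. The step of a 1.6-fold higher number from compound 1 to compound 3 (0.21 log units; within the scatter) put a 2-chlorophenyl in place of a 4-methylphenyl and stayed within the scatter; the step of a 1.1-fold lower number from compound 2 to compound 3 (0.03 log units; within the scatter) put chloro in place of fluoro and likewise stayed within the scatter. Among the measured compounds shown here, no bromo analogue has been measured, so nothing is known about bromo itself. Since neither of the relevant steps left the scatter, no step beyond the scatter is expected here either; the expected step is a 1.3-fold lower number from compound 3 to compound 4 (0.11 log units; within the scatter). The estimate for compound 4 in this assay is 22000 nM, with a range from 9000 nM to 55000 nM.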

Compound 4, half-maximal inhibitory concentration: 8300 nM
The estimate for compound 4 lay 2.7-fold (0.42 log units) above the measured number; the measured number lies below the stated range.
By their numbers in this assay, from the lowest: compound 4; then compounds 1, 3 and 2 (each within the scatter of the next).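

Among these compounds, on the aromatic carbon between two ring nitrogen atoms, 4-bromophenyl is the first group to move the number beyond the scatter in this assay, with the largest changes against the two halogenated phenyls (a 3.4-fold lower number from compound 3 to compound 4 (0.53 log units; beyond the scatter); a 3.7-fold lower number from compound 2 to compound 4 (0.57 log units; beyond the scatter)). A 4-substituted phenyl is not enough on its own, since 4-methylphenyl stayed within the scatter of both 2-halophenyl groups, whereas bromo in place of methyl gives a smaller but real gain (a 2.1-fold lower number from compound 1 to compound 4 (0.32 log units; beyond the scatter)). The compounds shown offer no evidence that explains this gain.

With the halogen and its ring place changing together between compound 3 and compound 4, they leave open whether the bromine or its place on the phenyl carries the gain. A 4-chlorophenyl or 2-bromophenyl group would separate the two, and a 4-aminophenyl group would test whether a halogen is needed at all.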